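Swapping tert-Butyl for 1-Methylcyclopropyl on the Carbamate

The source may hold more compounds than are shown below. What is called first, only, known or untested is meant among the compounds shown, and "the series" means these compounds.

Compound 1 `CCCOc1c(C(=O)N(C)Cc2cc(C(F)(F)F)cc(C(F)(F)F)c2)c(=O)n(C)c2ccccc12` is recorded in an assay for inhibition of phosphatidylcholine:ceramide cholinephosphotransferase 2 (Mus musculus), read by mass spectrometry, with stated times of 60 min and 30 min (a lower number here means a stronger inhibitor, a higher number a weaker inhibitor), as "not determined" (no result reported), so it has no usable number. Among the measured compounds shown here, compound 2 `COc1cc(CN(C)C(=O)c2c(OCCCC3CCN(C(=O)OC(C)(C)C)CC3)c3cccnc3n(C)c2=O)cc(OC)c1` gives 32 nM in this assay, the only number available, so it stands alone as the point of reference. Compound 3 `COc1cc(CN(C)C(=O)c2c(OCCCC3CCN(C(=O)OC4(C)CC4)CC3)c3cccnc3n(C)c2=O)cc(OC)c1` differs from compound 2 by 1-methylcyclopropyl in place of tert-butyl on an oxygen next to a carbonyl group. For the measured compounds named here, with no measured step to guide it, the change is expected to shift the result by a 1.1-fold higher number from compound 2 to compound 3 (0.04 log units; within the scatter), a step that would fall within the usual scatter rather than beyond it. Compound 3 is therefore estimated at 35 nM, within 15 nM to 80 nM.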

Compound 3, half-maximal inhibitory concentration: 14 nM
Compound 3: middle estimate off by 2.5-fold (0.40 log units), on the high side, outside the stated range (below it).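

In this assay, 1-methylcyclopropyl in place of tert-butyl on an oxygen next to a carbonyl group gives a 2.3-fold lower number from compound 2 to compound 3 (0.36 log units; beyond the scatter). The step is modest but beyond the scatter, so this position responds to a swap between two groups of equal heavy-atom count, of which only the entering one holds a three-membered ring. No measurement at hand gives a reason for this step.

On these data alone, how 1-methylcyclobutyl, cyclopropyl or isopropyl on this oxygen would read stays open. So does whether the same swap would give a similar step on another core.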